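A Methyl Added to the Isopropyl of Compound 1

A few compounds are considered here, and "the series" means these few. Any claim that something is new, unique, unknown or untested is made for them only; others in the source may bear on it.

Compound 1 `CC(C)c1cc2c(N/N=C\c3cccnc3)ncnc2s1` stands second highest of the three numbers in a functional assay on PC-6 cells (Homo sapiens) for antiproliferative activity (on this read-out lower numbers stand for stronger inhibition and higher numbers for weaker inhibition), where compound 1 gives 0.889 ug/mL. Its nearest neighbour is compound 2 `CC(C)c1cc2c(N/N=C\c3ccccc3)ncnc2s1`, which in this assay gives 0.651 ug/mL; the step of a 1.4-fold lower number from compound 1 to compound 2 (0.14 log units; within the scatter) stays inside the scatter. Furthest away is compound 3 `CC(C)c1cc2c(N/N=C\c3ccco3)ncnc2s1`, which in this assay gives 3.78 ug/mL, reached by a 4.3-fold higher number from compound 1 to compound 3 (0.63 log units; beyond the scatter); the step of a 5.8-fold higher number from compound 2 to compound 3 (0.76 log units; beyond the scatter) points the same way. All three measured steps exchange the ring on the carbon with the double bond to nitrogen and leave the rest of the shared core untouched. The change to compound 4 `CC(C)(C)c1cc2c(N/N=C\c3cccnc3)ncnc2s1` is of another kind: methyl in place of hydrogen on a saturated chain carbon bound to an aromatic carbon and two saturated chain carbons, so that isopropyl becomes tert-butyl. For the measured compounds named here, no measured step touches this part of the molecule, and the data give no direction for it. With nothing pointing either way, the number for compound 4 is expected to move by a 1.0-fold higher number from compound 1 to compound 4 (0.01 log units; within the scatter), no more than the scatter. Compound 4 is therefore estimated at 0.9 ug/mL in this assay, with a range from 0.35 ug/mL to 2.3 ug/mL.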

Compound 4, half-maximal inhibitory concentration: 1.45 ug/mL
Estimate against measurement, compound 4: 1.6-fold (0.21 log units) below; the range from low to high includes it.
By their numbers in this assay, from the lowest: compounds 2, 1 and 4 (each within the scatter of the next, the first and the last beyond it); then compound 3.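

In this assay, the change from isopropyl to tert-butyl gives a 1.6-fold higher number from compound 1 to compound 4 (0.21 log units; within the scatter), so the one added methyl on a saturated chain carbon bound to an aromatic carbon and two saturated chain carbons leaves the read-out inside the scatter. For the compounds shown here, this is the first view of this part of the molecule, and it rests on a single pair with the pyridin-3-yl ring in place, so it shows that this one enlargement of the chain is accommodated, not that the position is insensitive in general. Nothing available explains this result.

From the compounds shown here alone, whether tert-butyl behaves the same way alongside the phenyl or furan-2-yl ring remains open. So does the outcome for a different group at this place, such as a cyclohexyl ring, an amine or a carboxylic acid.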